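This account rests on a few compounds, and the source may have more. Where it says the series, first, only, none or still open, it means among the compounds named here.

Compound 1 `CCCCCCCCCCOP(=O)(O)OCCSC(=S)N1CCCC1`: > 100000 nM
Compound 2 `CCCCCCOP(=O)(O)OCCSC(=S)N1CCCC1`: > 100000 nM
Compound 3 `CCCCCCCCCCCCCCCCOP(=O)(O)OCCSC(=S)N1CCN(C)CC1`: > 100000 nM

Of the compounds shown here, three have been tested in an ADME assay on HEK293 cells (Homo sapiens) for inhibition, read by MTT assay, with stated times of 18 h and 4 h; on this read-out higher numbers stand for weaker inhibition and lower numbers for stronger inhibition. Compound 1 gives > 100000 nM, which is a limit of the assay and not a number. Compound 2 also reaches only a limit, > 100000 nM. Compound 3 likewise stops at a limit, > 100000 nM. All three sit together at the limit of > 100000 nM in this assay, at which 3 of the 3 values shown sit, so compound 1 cannot be separated from the other two on these numbers. Among the compounds with values here, the one step between measured compounds, hydrogen in place of butyl on a saturated chain carbon, six bonds along the chain from an oxygen on an unsaturated carbon, is a step that the two limits leave unreadable from compound 1 to compound 2.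

Compound 4 `CCCCCCCCCCOP(=O)(O)OCCSC(=S)N1CCCCCC1` differs from compound 1 in azepan-1-yl in place of pyrrolidin-1-yl on a thiocarbonyl carbon. Within the data shown here, no measured step touches this ring, and the only measured step gives no readable size, so no direction or size beyond the scatter can be expected for this change in this assay. The step expected is a step that the limit leaves unreadable from compound 1 to compound 4, most likely ending again at a limit. Compound 4 is estimated at 150000 nM, in the range 50000 nM to 500000 nM.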

Compound 4, half-maximal inhibitory concentration: 70000 nM
The estimate for compound 4 lay 2.1-fold (0.33 log units) above the measured number, within the range that was stated.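

In this assay, compound 4 is the only compound shown that gives a number and not a limit, so this change on the thiocarbonyl carbon is the one place where the read-out moves off the limit. Azepan-1-yl in place of pyrrolidin-1-yl gives an at least 1.4-fold lower number from compound 1 to compound 4 (0.15 log units; that floor lies within the scatter) in this read-out, and nothing firmer can be said of its direction. The full size of this step cannot be read, and neither can the earlier step between two limits, because those values are limits and not numbers: the limit of > 100000 nM in this assay, at which 3 of the 4 values shown sit.

Still open, as far as these compounds go, is whether a piperidine ring, or a ring carrying an amine or a carboxylic acid, would give a number in this place on the thiocarbonyl carbon. From the compounds shown here alone, it is also open whether azepan-1-yl would give a number with a shorter or a longer chain on the phosphate.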